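Swapping Thiophen-3-yl for 3-Fluorophenyl and Cell Toxicity

A few compounds are considered here, and "the series" means these few. Any claim that something is new, unique, unknown or untested is made for them only; others in the source may bear on it.

Measured so far:
- Compound 1, `COc1nc(-c2ccsc2)ccc1[C@@H](c1ccccc1)[C@@](O)(CCN(C)C)c1cccc2ccccc12`: 24.4 ug/mL
- Compound 2, `COc1ncc(-c2ccccc2)cc1[C@@H](c1ccccc1)[C@@](O)(CCN(C)C)c1cc(F)ccc1F`: > 50 ug/mL, which is a limit of the assay rather than a number

In a toxicity assay on Vero cells (Chlorocebus sabaeus) for cytotoxicity (on this read-out lower numbers stand for higher toxicity in this test and higher numbers for lower toxicity in this test), compound 1 gives 24.4 ug/mL. For the measured compounds named here, this is the only actual number recorded here. The other reading belongs to compound 2 and is a limit, as described by the limit of > 50 ug/mL in this assay, at which 1 of the 2 values shown sits. Compound 1 therefore cannot be ranked against compound 2 beyond saying that its toxicity was measurable where that of compound 2 was not.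

The unmeasured compound 3, `COc1nc(-c2cccc(F)c2)ccc1[C@@H](c1ccccc1)[C@@](O)(CCN(C)C)c1cccc2ccccc12`, keeps the core of compound 1 and changes one group: 3-fluorophenyl in place of thiophen-3-yl on an aromatic carbon. Going by the values given here, no measured pair in this set isolates such a change, so the size of its effect in this assay is unknown. Without such evidence, the sensible expectation is a step from compound 1 to compound 3 that stays within the usual scatter, in no particular direction; this is what a 1.0-fold higher number from compound 1 to compound 3 (0.01 log units; within the scatter) is estimated to be.

Compound 3 is thus expected to give about 25 ug/mL in this assay, with a likely range from 12 ug/mL to 50 ug/mL.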

Compound 3, half-maximal cytotoxic concentration: > 50 ug/mL
Compound 3 gave a limit, no number; the forecaster's own chance of this, stated with the estimate: 20%; middle value at least 2.0-fold (0.30 log units) from the limit.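

Putting 3-fluorophenyl in place of thiophen-3-yl on the aromatic carbon next to the ring nitrogen gives an at least 2.0-fold higher number from compound 1 to compound 3 (0.31 log units; beyond the scatter) in this assay. For the compounds shown here, this is the first comparison here between two compounds that differ in one place only, and it shows that the group at this position can move the read-out beyond the usual scatter, towards lower toxicity in this test for the 3-fluorophenyl compound. The full size of the step stays unknown, as the reading for compound 3 is a limit and not a number: the limit of > 50 ug/mL in this assay, at which 2 of the 3 values shown sit.

This single swap changes several things together: a five-membered ring becomes a six-membered ring, and the sulfur gives way to a fluorine, so the compounds shown cannot tell which of these changes matters, or whether the other ring carbons of the new group would serve the fluorine equally well. They also leave open how this assay would respond to quite different groups at this position, such as a plain phenyl ring, a morpholine or a carboxylic acid.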